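The source may report more compounds than this note shows. Statements on the series, on what has been measured and on what is new or still open speak of the compounds shown alone.

The measured compounds, all tested in a functional assay, read by Griess assay, with a stated time of 150 min, tested at 100 ug/mL; on this read-out lower numbers stand for a weaker effect and higher numbers for a stronger effect at the one concentration tested:

Compound 1, `COc1ccc(C2=NN(c3ccccc3)C(c3ccc(C)cc3)C2S(=O)(=O)CC2=NCCO2)cc1`: 70.5%
Compound 2, `O=S(=O)(CC1=NCCS1)c1c(-c2ccc(Cl)cc2)noc1-c1ccc(Cl)cc1`: "not active" (no number reported)
Compound 3, `COc1ccc(C2=NN(c3ccccc3)C(c3ccc(C)cc3)C2S(=O)(=O)CC2=NCCS2)cc1`: 50.7%

Compounds 1 and 3 share a core and differ in one place. The change is a group of 5 heavy atoms (3 carbon, 1 nitrogen, 1 oxygen; one five-membered non-aromatic ring with 2 hetero atoms) in place of a group of 5 heavy atoms (3 carbon, 1 nitrogen, 1 sulfur; one five-membered non-aromatic ring with 2 hetero atoms), on a saturated chain carbon bound to a sulfonyl sulfur. Its effect is a number 19.8 percentage points higher from compound 3 to compound 1 (beyond the scatter). Compound 2 is built on a different core; the difference between the two cores is not broken down here. For compound 2 this assay reports only that it is not active, without a number.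

Compound 4, `O=S(=O)(CC1=NCCO1)c1c(-c2ccc(Cl)cc2)noc1-c1ccc(Cl)cc1`, is the not yet measured partner of compound 2. The change from compound 2 to compound 4 is a group of 5 heavy atoms (3 carbon, 1 nitrogen, 1 oxygen; one five-membered non-aromatic ring with 2 hetero atoms) in place of a group of 5 heavy atoms (3 carbon, 1 nitrogen, 1 sulfur; one five-membered non-aromatic ring with 2 hetero atoms), on a saturated chain carbon bound to a sulfonyl sulfur. This is the same change seen from compound 3 to compound 1, made at the same place: it occurs two times among the compounds shown.

What can be expected for compound 4 in this assay rests on two things: the step from compound 3 to compound 1, which was of modest size, and the starting point of compound 2, which gave no number at all. A modest gain added to a compound that showed no measurable effect is not expected to carry compound 4 far. Compound 4 is therefore estimated at 15%, expected to lie between 0% and 40%, with a real chance that it too is reported only as not active.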

Compound 4, a percentage reported as activity, at one concentration (the size of the read-out at that concentration, not a potency): "not active" (no number reported)
Compound 4 has no reported number here; the estimate stays without a comparison.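

Compound 2 and compound 4 are both reported only as not active in this assay, and no step can be read between them. The compounds shown leave open whether replacing the sulfur-containing ring with the oxygen-containing ring has any effect on the core of compound 2. No measured evidence shown here bears on this result.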